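A few compounds are considered here, and "the series" means these few. Any claim that something is new, unique, unknown or untested is made for them only; others in the source may bear on it.

Measured in a functional assay on DU-145 cells (Homo sapiens) for inhibition, read by trypan blue exclusion, with a stated time of 96 h; on this read-out higher numbers stand for weaker inhibition of growth and lower numbers for stronger inhibition of growth:
compound 1 `O=C(/C(=C\c1ccc(Br)c(O)c1)S(=O)(=O)c1ccc(Br)cc1)c1ccc(Br)cc1` gives 50000 nM
compound 2 `Cc1ccsc1/C=C(/SCc1ccccc1F)C(=O)c1ccc(Cl)cc1` gives 50000 nM
compound 3 `Cc1ccc(CS(=O)(=O)/C(=C/c2ccccc2Br)C(=O)c2ccc(Cl)cc2)cc1` gives 25000 nM

In this assay compound 1 stands level with compound 2 at the digits shown, the two together the highest of the three numbers, and the number of compound 3 lies within the scatter of theirs. All three therefore read as weak inhibitors of growth. The unmeasured compound 4 `O=C(/C(=C\c1ccc(F)cc1Cl)S(=O)(=O)c1ccc(Br)cc1)c1ccc(Br)cc1` keeps the core of compound 1 and differs in one place: 2-chloro-4-fluorophenyl in place of 4-bromo-3-hydroxyphenyl on a double-bonded chain carbon bound to a double-bonded chain carbon. Within the data shown here, no step between measured compounds isolates an exchange of this kind, so nothing here shows which way it should go. The step from compound 1 to compound 4 is expected to be a 1.1-fold lower number from compound 1 to compound 4 (0.05 log units; within the scatter), no larger than the scatter. Compound 4 is therefore estimated at 45000 nM, with a range from 20000 nM to 60000 nM.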

Compound 4, concentration for 50% growth inhibition: 50000 nM
Compound 4: middle estimate off by 1.1-fold (0.05 log units), on the low side, within the range that was stated.
By their numbers in this assay, from the lowest: compounds 3, 1, 2 and 4 (each within the scatter of the next).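

In this assay, 2-chloro-4-fluorophenyl in place of 4-bromo-3-hydroxyphenyl on a double-bonded chain carbon bound to a double-bonded chain carbon gives no change at the digits printed from compound 1 to compound 4 (within the scatter). The group that leaves carries a hydrogen-bond donor and the group that enters carries none, yet both compounds remain weak inhibitors of growth, so this exchange does not improve growth inhibition. Nothing available explains why the number holds.

On these data alone, whether an amine or a carboxylic acid in this place would give a lower number remains open. So does whether the same exchange would read alike on another core.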